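Swapping the Anilide Ring While Keeping Low Cytotoxicity

This account rests on a few compounds, and the source may have more. Where it says the series, first, only, none or still open, it means among the compounds named here.

Compound 3 `COc1ccc(-c2nnsc2SCC(=O)Nc2ccccc2Cl)cc1` was examined in an ADME assay on MT4 cells (Homo sapiens) for cytotoxicity; on this read-out higher numbers stand for lower toxicity in this test and lower numbers for higher toxicity in this test. In this assay compound 3 gives > 318000 nM, which is a limit of the assay rather than a measured number. The two other compounds stand in the same way. Compound 1 `Cc1ccc(NC(=O)CSc2snnc2-c2ccccc2)c(Br)c1` gives > 297000 nM in this assay, again a limit. Compound 2 `Cc1ccc(NC(=O)CSc2snnc2-c2ccc(Cl)cc2Cl)c(Br)c1` gives > 255000 nM in this assay, also a limit. Because both ends are limits, a step that the two limits leave unreadable from compound 1 to compound 2 cannot be read as a size.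

Compound 4 `COc1ccc(-c2nnsc2SCC(=O)Nc2ccc(C)cc2Br)cc1` differs from compound 3 by 2-bromo-4-methylphenyl in place of 2-chlorophenyl on an amide-type nitrogen. The group that enters is the same anilide ring carried by compound 1 and compound 2, whose values sit at the limit of > 297000 nM in this assay, at which 1 of the 3 values shown sits, and (the limit of > 255000 nM in this assay, at which 1 of the 3 values shown sits). Within the data shown here, no measured step bears directly on this change, and all three known values point to low toxicity. No shift beyond the scatter is therefore expected; the expected step is an at least 1.0-fold lower number from compound 3 to compound 4 (0.02 log units; that floor lies within the scatter). Compound 4 is expected to give 300000 nM in this assay, with a range from 150000 nM to 600000 nM, most likely reported again only as a limit.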

Compound 4, half-maximal cytotoxic concentration: 249000 nM
For compound 4 the middle estimate is 1.2-fold (0.08 log units) above the measured one; the measured number falls inside the stated range.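

In this assay compound 4 gives 249000 nM, a measured number. The three earlier compounds gave only limits, so this series now has one firm value to stand on. Changing the ring on the amide-type nitrogen gives an at least 1.2-fold lower number from compound 3 to compound 4 (0.10 log units; that floor lies within the scatter), while the changes on the aromatic carbon at the other end give an at least 1.0-fold lower number from compound 2 to compound 4 (0.01 log units; that floor lies within the scatter) and an at least 1.1-fold lower number from compound 1 to compound 4 (0.07 log units; that floor lies within the scatter). Each of these floors lies within the scatter, but each step starts from a limit, so its true size stays unfixed, and low toxicity in this test holds for 2-bromo-4-methylphenyl as it does for 2-chlorophenyl only as far as these numbers reach.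

The compounds shown carry only halogen and methyl groups on this anilide ring. From the compounds shown here alone, how a ring bearing an amine or a carboxylic acid would behave at this position remains open.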